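The source may hold more compounds than are shown below. What is called first, only, known or untested is meant among the compounds shown, and "the series" means these compounds.

Compound 2, `COc1ccc(CNc2nc3cc(N)cc(N)c3nc2-c2ccccc2)cc1OC`, carries a 3,4-dimethoxyphenyl group on the saturated chain carbon bound to the ring nitrogen, where compound 1, `Nc1cc(N)c2nc(-c3ccccc3)c(NCc3ccc(Cl)c(Cl)c3)nc2c1`, has a 3,4-dichlorophenyl group. In a functional assay on SF-295 cells (Homo sapiens) for inhibition, read by sulforhodamine B assay, with a stated time of 48 h (on this read-out higher numbers stand for weaker inhibition of growth and lower numbers for stronger inhibition of growth), compound 2 gives 13200 nM, and compound 1 gives 15500 nM; the two numbers lie within the scatter of each other, so compound 2 cannot be set apart from compound 1 on this assay. Within the data shown here, the one measured step, a 1.2-fold lower number from compound 1 to compound 2 (0.07 log units; within the scatter), shows that exchanging the substituents on that phenyl ring left the read-out essentially where it was.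

Compound 3, `COc1cc(CNc2nc3cc(N)cc(N)c3nc2-c2ccccc2)cc(OC)c1OC`, differs from compound 2 in a single place: methoxy in place of hydrogen on an aromatic carbon. Among the measured compounds shown here, no measured step involves a methoxy group at this position; the only step that bears on the question is the one from compound 1 to compound 2, which altered the same phenyl ring without a change beyond the scatter. On that basis compound 3 is expected to stay close to compound 2, with a step of about a 1.1-fold lower number from compound 2 to compound 3 (0.02 log units; within the scatter), in no direction that exceeds the scatter. In this assay compound 3 is therefore estimated at 12500 nM, within a range from 5000 nM to 32000 nM.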

Compound 3, concentration for 50% growth inhibition: 1660 nM
Compound 3: middle estimate off by 7.5-fold (0.88 log units), on the high side, and the stated range ends above it.
By their numbers in this assay, from the lowest: compound 3; then compounds 2 and 1 (each within the scatter of the next).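

In this assay, a methoxy group on this aromatic carbon, ortho to a methoxy group and meta to a large group, gives an 8.0-fold lower number from compound 2 to compound 3 (0.90 log units; beyond the scatter), and so stronger inhibition of growth. This is the first step beyond the scatter among the compounds shown: the earlier change on the same phenyl ring, a 1.2-fold lower number from compound 1 to compound 2 (0.07 log units; within the scatter), stayed within it and gave no sign that the read-out could respond to a change on this ring. The result shows that it can, and that a single added methoxy group in place of hydrogen is enough, though nothing measured here accounts for the size of this step.

The compounds shown leave open whether this step belongs to the methoxy group itself or would also come with an ethoxy group, a hydroxyl group or a chlorine atom on the same aromatic carbon. They also leave open whether a methoxy group on this carbon would give a similar step without the two methoxy groups that compound 2 already carries.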